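A few compounds are considered here, and "the series" means these few. Any claim that something is new, unique, unknown or untested is made for them only; others in the source may bear on it.

Measured in a functional assay on A549 cells (Homo sapiens) for cytotoxicity, read by MTT assay; on this read-out higher numbers stand for weaker inhibition and lower numbers for stronger inhibition:
compound 1 `CCn1cc(C(=O)Nc2ccccc2)c(=O)c2cc(F)c(N3CCNC(C)C3)c(F)c21`: 39300 nM
compound 2 `CCn1cc(C(=O)Nc2ccc(Cl)cn2)c(=O)c2cc(F)c(N3CCNC(C)C3)c(F)c21`: 3300 nM
compound 3 `CCn1cc(C(=O)Nc2cc([N+](=O)[O-])ccc2F)c(=O)c2cc(F)c(N3CCNC(C)C3)c(F)c21`: 1700 nM

Compound 1 gives the highest number of the three. The nearest measured neighbour is reached by a 12-fold lower number from compound 1 to compound 2 (1.08 log units; beyond the scatter), the furthest by a 23-fold lower number from compound 1 to compound 3 (1.36 log units; beyond the scatter); the two values of compound 2 and compound 3 lie within the scatter of each other.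

Compound 4 `CCn1cc(C(=O)Nc2ccc(OC(F)(F)F)cc2)c(=O)c2cc(F)c(N3CCNC(C)C3)c(F)c21` differs from compound 1 by trifluoromethoxy in place of hydrogen on an aromatic carbon. Both measured steps from compound 1 also altered the aromatic ring on the amide-type nitrogen and both gave large lower numbers, so they bear on this step, though neither adds a trifluoromethoxy group, and the size here is uncertain. A lower number is expected in this assay, but smaller than either measured step. Compound 4 is estimated at 12000 nM, between 4000 nM and 36000 nM, an expected step of a 3.3-fold lower number from compound 1 to compound 4 (0.52 log units; beyond the scatter).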

Compound 4, half-maximal inhibitory concentration: 1320 nM
The estimate for compound 4 lay 9.1-fold (0.96 log units) above the measured number, outside the stated range (below it).
By their numbers in this assay, from the lowest: compounds 4, 3 and 2 (each within the scatter of the next, the first and the last beyond it); then compound 1.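

In this assay, a single trifluoromethoxy group on an aromatic carbon, para to a large group, gives a 30-fold lower number from compound 1 to compound 4 (1.47 log units; beyond the scatter) and so one substituent on the phenyl ring suffices for a large shift. Compound 4 is not separated from compound 3 by a 1.3-fold lower number from compound 3 to compound 4 (0.11 log units; within the scatter) but is separated from compound 2 by a 2.5-fold lower number from compound 2 to compound 4 (0.40 log units; beyond the scatter) as a modest step. Nothing available accounts for these shifts.

As far as these compounds go, it remains open whether the shift is specific to trifluoromethoxy or would also follow from methoxy, an amine or a carboxylic acid on the same carbon. From the compounds shown here alone, the effect of moving trifluoromethoxy to another ring carbon also remains open.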